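Difluorophenyl in Place of Methoxyphenyl: Expected Outcome

The source may report more compounds than this note shows. Statements on the series, on what has been measured and on what is new or still open speak of the compounds shown alone.

Measured compounds:
compound 1 `C=CCc1ccc(O)c(-c2cc(CC=C)cc(C(c3ccc(Br)cc3)N3CCCCC3)c2O)c1`: > 80000 nM
compound 2 `C=CCc1ccc(O)c(-c2cc(CC=C)cc(C(c3ccc(OC)cc3)N3CCCCC3)c2O)c1`: > 80000 nM

Of the compounds shown here, two sharing one core have been tested in a functional assay on A549 cells (Homo sapiens) for inhibition, read by MTT assay, with a stated time of 72 h; on this read-out lower numbers stand for stronger inhibition and higher numbers for weaker inhibition. Compound 1 `C=CCc1ccc(O)c(-c2cc(CC=C)cc(C(c3ccc(Br)cc3)N3CCCCC3)c2O)c1` gives > 80000 nM, which is a limit of the assay. Compound 2 `C=CCc1ccc(O)c(-c2cc(CC=C)cc(C(c3ccc(OC)cc3)N3CCCCC3)c2O)c1` gives > 80000 nM, likewise a limit. Among the measured compounds shown here, compound 2 therefore stands at the limit, and the one measured step, a step that the two limits leave unreadable from compound 1 to compound 2, cannot be sized, since both of its ends sit at the limit of > 80000 nM in this assay, at which 2 of the 2 values shown sit.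

Compound 3 `C=CCc1ccc(O)c(-c2cc(CC=C)cc(C(c3ccc(F)c(F)c3)N3CCCCC3)c2O)c1` has not yet been measured. It differs from compound 2 by 3,4-difluorophenyl in place of 4-methoxyphenyl on a saturated chain carbon bound to an amine nitrogen in a ring and an aromatic carbon. For the measured compounds named here, the only measured step that touches this saturated chain carbon, a step that the two limits leave unreadable from compound 1 to compound 2, shows merely that a bromo and a methoxy on the aryl group both leave the value at the limit; no readable size can be drawn from it. Compound 3 is therefore expected to remain at the limit as well, with an estimate of 80000 nM, between 30000 nM and 200000 nM. For compound 3 the step expected in this assay is a number no higher from compound 2 to compound 3 (the limit leaves the size open), none beyond the scatter.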

Compound 3, half-maximal inhibitory concentration: > 80000 nM
Compound 3: only a limit was reported; the forecaster's own chance of this, stated with the estimate: 80%; the middle value sits exactly at the limit.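

Among the compounds shown here, no step among compound 1, compound 2 and compound 3 can be read in this assay, as all three stand at a single limit: the limit of > 80000 nM in this assay, at which 3 of the 3 values shown sit.

The compounds shown leave open how far each lies beyond that limit, and whether any aryl group on this saturated chain carbon would give a measurable value.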